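The compounds below may be only part of what the source reports. "The series", "measured", "known", "first", "only" and "open" are said of these compounds alone.

Measured so far:
compound 1 `Cc1cc(/C=C/C#N)cc(C)c1Oc1ccc([N+](=O)[O-])c(Nc2ccc(C#N)cc2)n1` — > 100000 nM
compound 2 `Cc1cc(/C=C/C#N)cc(C)c1Oc1ccc([N+](=O)[O-])c(Nc2ccc(C#N)cc2)c1` — > 100000 nM
compound 3 `Cc1cc(/C=C/C#N)cc(C)c1Oc1ccc(N)c(Nc2ccc(C#N)cc2)n1` — 5630 nM

Three compounds were tested in an ADME assay on MT2 cells (Homo sapiens) for cytotoxicity, read by XTT assay, with a stated time of 4 days; a lower number here means that less compound is tolerated, a higher number that more compound is tolerated. For compound 1 the value in this assay is a limit of the assay, > 100000 nM. For compound 2 the value is likewise a limit, > 100000 nM. Compound 3, by contrast, gives a number, 5630 nM. The step of an at least 17-fold lower number from compound 1 to compound 3 (1.24 log units; beyond the scatter) comes from amino in place of nitro on an aromatic carbon; its true size is only bounded, since the starting value sits at the limit of > 100000 nM in this assay, at which 2 of the 3 values shown sit.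

Compound 4 `Cc1cc(/C=C/C#N)cc(C)c1Oc1ccc(N)c(Nc2ccc(C#N)cc2)c1` has not yet been measured. It differs from compound 2 by amino in place of nitro on an aromatic carbon. The difference between the cores of compound 1 and compound 2 is not broken down here. The surroundings of the change are not identical: from compound 1 to compound 3 it sits on a six-membered aromatic ring with 1 nitrogen, two atoms from the ring nitrogen, whereas from compound 2 to compound 4 it sits on a six-membered aromatic ring of carbon only, so this is the same kind of change rather than the same change.

Because compound 2 also stands at the limit of > 100000 nM in this assay, at which 2 of the 3 values shown sit, the step from compound 2 to compound 4 is expected to be an at least 14-fold lower number from compound 2 to compound 4 (1.15 log units; beyond the scatter), set beside an at least 17-fold lower number from compound 1 to compound 3 (1.24 log units; beyond the scatter). Compound 4 is accordingly estimated at 7000 nM, between 2000 nM and 40000 nM.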

Compound 4, half-maximal cytotoxic concentration: 8830 nM
Compound 4: the middle estimate sits 1.3-fold (0.10 log units) below what was measured, within the range that was stated.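

In this assay, amino in place of nitro on an aromatic carbon again comes with a large step, an at least 11-fold lower number from compound 2 to compound 4 (1.05 log units; beyond the scatter), so the direction seen on the core of compound 1 is also seen on the core of compound 2. This shows that the change carries over in direction between these two cores, but it does not show that it carries over in size: the same change on two cores in this assay, an at least 17-fold lower number (1.24 log units; beyond the scatter) from compound 1 to compound 3 and an at least 11-fold lower number (1.05 log units; beyond the scatter) from compound 2 to compound 4; the limit leaves it open whether they differ Compound 1 and compound 2 both stand at a limit of the assay and not at a number, so each step is bounded on one side only: the limit of > 100000 nM in this assay, at which 2 of the 4 values shown sit.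

The compounds shown leave open how a group other than amino or nitro in that place, such as a hydroxyl, a methylamino group or an acetamide, would read in this assay. They also leave open whether the same change would give a step of this direction on any core other than these two.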